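From pyridin-4-yl to 4-chlorophenyl on a shared core

The source may hold more compounds than are shown below. What is called first, only, known or untested is meant among the compounds shown, and "the series" means these compounds.

Measured in a physicochemical assay for lipophilicity, read by HPLC (on this read-out lower numbers stand for lower lipophilicity and higher numbers for higher lipophilicity), so far:
- compound 1 `O=C1/C(=C/c2ccncc2)C(c2ccccc2)Oc2ccccc21` gives 2.98
- compound 2 `O=C1/C(=C\c2ccncc2)C(c2ccccc2)Oc2ccccc21` gives 2.85
- compound 3 `O=C1/C(=C/c2ccccc2)C(c2ccccc2)Oc2ccc(O)cc21` gives 3.5

Compound 1 with 2.98 stands level with compound 2, within the scatter, while compound 3 lies higher, beyond the scatter. Compound 4 `O=C1/C(=C/c2ccc(Cl)cc2)C(c2ccccc2)Oc2ccccc21` has not been measured yet, and it differs from compound 1 in one place: 4-chlorophenyl in place of pyridin-4-yl on a double-bonded chain carbon bound to a double-bonded ring carbon. Among the measured compounds shown here, the one measured step of a number 0.13 log units lower from compound 1 to compound 2 (within the scatter) only turns a double bond from E to Z and exchanges no group, so it gives no size for this change. The expectation therefore rests on the exchange itself, which removes a hydrogen-bond acceptor and brings in chlorine. Starting from compound 1 with 2.98, a rise beyond the scatter is expected in this assay, though no measured step confirms this. The expected size is an estimate: a number 1.72 log units higher from compound 1 to compound 4 (beyond the scatter) (without a measured precedent). For compound 4 the estimated value is 4.7, with an expected range from 4 to 5.4.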

Compound 4, partition coefficient: 4.46
For compound 4 the middle estimate is 0.24 log units above the measured one, within the range that was stated.
By their numbers in this assay, from the lowest: compounds 2 and 1 (each within the scatter of the next); then compound 3; then compound 4.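

In this assay, among the compounds shown here, putting 4-chlorophenyl in place of pyridin-4-yl on the double-bonded chain carbon gives a number 1.48 log units higher from compound 1 to compound 4 (beyond the scatter) and so provides the first measured exchange of one group for another at this place. The earlier step at this double bond only turned it from E to Z and stayed within the scatter, whereas this exchange of the aromatic ring moves the number well beyond it. The data shown here offer no measured explanation for the size of this step.

The exchange removes the ring nitrogen and adds chlorine at once, so a plain phenyl at this place on the core of compound 1 would be needed to tell their shares apart. From the compounds shown here alone, it also remains open how a 4-aminophenyl or 4-carboxyphenyl group would read here, and whether the step keeps its size with the double bond drawn Z.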